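Replacing the 3-hydroxyphenyl group of compound 3

The source may hold more compounds than are shown below. What is called first, only, known or untested is meant among the compounds shown, and "the series" means these compounds.

In a functional assay on MCF7 cells (Homo sapiens) for antiproliferative activity, read by MTT assay, with stated times of 24 h and 72 h (a higher number here means a weaker inhibitor, a lower number a stronger inhibitor), compound 1 `COc1cccc([C@@H]2[C@H](Oc3ccccc3)C(=O)N2c2cc(OC)c(OC)c(OC)c2)c1` gives 171000 nM, compound 2 `COc1cc(N2C(=O)[C@@H](Oc3ccccc3)[C@H]2c2ccc(N(C)C)cc2)cc(OC)c1OC` gives 31000 nM and compound 3 `COc1cc(N2C(=O)[C@@H](Oc3ccccc3)[C@H]2c2cccc(O)c2)cc(OC)c1OC` gives 54000 nM. Two steps fix where the last of these stands: a 3.2-fold lower number from compound 1 to compound 3 (0.50 log units; beyond the scatter), and a 1.7-fold higher number from compound 2 to compound 3 (0.24 log units; within the scatter). The remaining measured step is a 5.5-fold lower number from compound 1 to compound 2 (0.74 log units; beyond the scatter).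

Compound 4 `COc1ccc([C@@H]2[C@H](Oc3ccccc3)C(=O)N2c2cc(OC)c(OC)c(OC)c2)c(N)c1O` differs from compound 3 at one place: a group of 10 heavy atoms (7 carbon, 1 nitrogen, 2 oxygen; one six-membered aromatic ring of carbon only) in place of a group of 7 heavy atoms (6 carbon, 1 oxygen; one six-membered aromatic ring of carbon only), on a saturated ring carbon. Going by the values given here, no measured compound carries the entering group, so the three steps offer a guide to size and not a direct precedent. Among the compounds with values here, both changes away from compound 1 gave a modest fall in the number, and none of the measured steps was large. A modest fall is therefore expected here too, with wide uncertainty in this assay. The expected change is a 5.4-fold lower number from compound 3 to compound 4 (0.73 log units; beyond the scatter). Compound 4 is estimated at 10000 nM, with an expected range from 300 nM to 60000 nM.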

Compound 4, half-maximal inhibitory concentration: 19000 nM
The estimate for compound 4 lay 1.9-fold (0.28 log units) below the measured number; the range from low to high includes it.
By their numbers in this assay, from the lowest: compounds 4, 2 and 3 (each within the scatter of the next, the first and the last beyond it); then compound 1.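

In this assay, the saturated ring carbon takes a larger group with more hydrogen-bond donors and acceptors than 3-hydroxyphenyl and the number still falls, with a 2.8-fold lower number from compound 3 to compound 4 (0.45 log units; beyond the scatter) and, against the 3-methoxyphenyl group, a 9.0-fold lower number from compound 1 to compound 4 (0.95 log units; beyond the scatter) as the widest step in the set. Against the 4-(dimethylamino)phenyl group the new group makes no clear difference, with a 1.6-fold lower number from compound 2 to compound 4 (0.21 log units; within the scatter), so two differently substituted aromatic rings at this carbon cannot be told apart here. No measurement bears on why these numbers move as they do.

The entering group carries an amino, a hydroxyl and a methoxy group on one ring, so the compounds shown cannot say which of these accounts for the step. They also leave open how a carboxylic acid on this ring would fare at the same carbon.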